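A few compounds are considered here, and "the series" means these few. Any claim that something is new, unique, unknown or untested is made for them only; others in the source may bear on it.

In an ADME assay on cells (Homo sapiens) for cytotoxicity, read by polymerase chain reaction, with a stated time of 3 days (on this read-out lower numbers stand for higher toxicity in this test and higher numbers for lower toxicity in this test), the measured compounds are:
compound 1 `Nc1nc(Cl)c(-c2nc3ccc(Cl)cc3s2)c(N[C@@H]2C[C@H](CO)[C@@H](O)[C@H]2O)n1`, 16000 nM;
compound 2 `CCOc1ccc2nc(-c3c(Cl)nc(N)nc3N[C@@H]3C[C@H](CO)[C@@H](O)[C@H]3O)sc2c1`, for which only a limit of the assay is reported, > 25000 nM;
compound 3 `CNc1ccc2nc(-c3c(Cl)nc(N)nc3N[C@@H]3C[C@H](CO)[C@@H](O)[C@H]3O)sc2c1`, 6000 nM.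

Compound 3 holds the lowest of the two plain numbers. Its nearest neighbour is compound 1, separated by a 2.7-fold lower number from compound 1 to compound 3 (0.43 log units; beyond the scatter), a gap beyond the scatter. The remaining value, that of compound 2, is a limit of the assay (the limit of > 25000 nM in this assay, at which 1 of the 3 values shown sits).

Compound 4 `CN(C)c1ccc2nc(-c3c(Cl)nc(N)nc3N[C@@H]3C[C@H](CO)[C@@H](O)[C@H]3O)sc2c1` differs from compound 3 by methyl in place of hydrogen on a nitrogen on an aromatic ring. Among the compounds with values here, none of the measured steps alters this nitrogen: an at least 1.5-fold higher number from compound 1 to compound 2 (0.19 log units; that floor lies within the scatter) and a 2.7-fold lower number from compound 1 to compound 3 (0.43 log units; beyond the scatter) exchange the whole group on the aromatic carbon, and an at least 4.1-fold lower number from compound 2 to compound 3 (0.61 log units; beyond the scatter) does the same. The data therefore give no direct guide to adding a methyl on the nitrogen, and the steps that exist are modest. Compound 4 is expected to sit close to compound 3, with a 1.2-fold higher number from compound 3 to compound 4 (0.07 log units; within the scatter) expected to remain within the scatter. The estimate for compound 4 is 7000 nM, with a range of 2500 nM to 20000 nM.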

Compound 4, half-maximal cytotoxic concentration: > 25000 nM
Compound 4: no number, only a limit; the forecaster's own chance of this, stated with the estimate: 15%; at least 3.5-fold (0.55 log units) between middle value and limit.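

In this assay, within the data shown here, the nitrogen on the aromatic ring responds to a single added carbon: methyl in place of hydrogen gives an at least 4.1-fold higher number from compound 3 to compound 4 (0.61 log units; beyond the scatter), whereas the earlier steps only exchanged the whole group on the aromatic carbon. Dimethylamino in place of chloro gives an at least 1.5-fold higher number from compound 1 to compound 4 (0.19 log units; that floor lies within the scatter), so unlike methylamino, dimethylamino does not bring the number below that of compound 1. Compound 2 and compound 4 both stand at a limit, so the step between them cannot be read: the limit of > 25000 nM in this assay, at which 2 of the 4 values shown sit.

The compounds shown leave open how far the number rises with the methyl, as compound 4 gives only a limit. They also leave open whether a free amino group, or a longer chain such as ethylamino or diethylamino, would follow methylamino or dimethylamino at this place.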